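This account rests on a few compounds, and the source may have more. Where it says the series, first, only, none or still open, it means among the compounds named here.

Notes on the series. Compound 1 `CCOC(=O)C1CCN(C(=O)CN2CN(c3ccccc3)C3(CCN(C(=O)c4ccc(C(C)(C)C)cc4)CC3)C2=O)CC1` gives 3100 nM in an assay on HEK293 cells for displacement of a labelled ligand from NPC1-like intracellular cholesterol transporter 1 (Homo sapiens); a higher number here means a weaker inhibitor, a lower number a stronger inhibitor. Among the measured compounds shown here, compound 2 `CC(C)(C)c1ccc(C(=O)N2CCC3(CC2)C(=O)N(CC(=O)N2CCCC(O)C2)CN3c2ccccc2)cc1` gives 12200 nM, the higher of the two numbers so far; the one measured step, a 3.9-fold higher number from compound 1 to compound 2 (0.59 log units; beyond the scatter), is modest and beyond the scatter. Compound 3 `CC(C)(C)c1ccc(C(=O)N2CCC3(CC2)C(=O)N(CC(=O)NCCCNS(C)(=O)=O)CN3c2ccccc2)cc1` is the next candidate: (3-(methanesulfonamido)propyl)amino in place of 3-hydroxypiperidin-1-yl on a carbonyl carbon. For the measured compounds named here, no measured step touches this change, so the expectation is weak. Compound 3 is estimated at 8000 nM, within a range of 2500 nM to 25000 nM. The expected step would be a 1.5-fold lower number from compound 2 to compound 3 (0.18 log units; within the scatter).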

Compound 3, half-maximal inhibitory concentration: 10400 nM
Beside the measured number, compound 3's estimate is 1.3-fold (0.11 log units) below it; low and high end bracket the measured number.
By their numbers in this assay, from the lowest: compound 1; then compounds 3 and 2 (each within the scatter of the next).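

At this position on a carbonyl carbon, the open chain (3-(methanesulfonamido)propyl)amino replacing the ring of 3-hydroxypiperidin-1-yl gives a 1.2-fold lower number from compound 2 to compound 3 (0.07 log units; within the scatter) in this assay, so neither the ring nor the different donor and acceptor counts separates the two compounds. Among the compounds shown here, the other comparison, a 3.4-fold higher number from compound 1 to compound 3 (0.53 log units; beyond the scatter), leaves 4-(ethoxycarbonyl)piperidin-1-yl as the only group of the three with a clearly lower number. No available evidence explains these results. Open, as far as these compounds go, is whether that lower number belongs to the ethyl ester or to the piperidine, which a plain piperidin-1-yl or a 4-carboxypiperidin-1-yl would help to separate.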